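The compounds below may be only part of what the source reports. "The series", "measured", "known", "first", "only" and "open" are said of these compounds alone.

Measured so far in an ADME assay on MT4 cells (Homo sapiens) for cytotoxicity; a lower number here means that less compound is tolerated, a higher number that more compound is tolerated:
Compound 1, `FC(F)(F)c1cccc(NC(=S)Nc2ccc(Cl)cc2)c1`, gives 6800 nM.
Compound 2, `O=[N+]([O-])c1ccc(NC(=S)Nc2cccc(C(F)(F)F)c2)cc1`, gives 9200 nM.

Compound 1 stands at the lowest of these two numbers, but its nearest neighbour, compound 2, differs from it only by a 1.4-fold higher number from compound 1 to compound 2 (0.13 log units; within the scatter), so the two are not separated in this assay. Compound 3, `CSCCCNC(=S)Nc1cccc(C(F)(F)F)c1`, is not yet measured. Its change from compound 1 is 3-(methylsulfanyl)propyl in place of 4-chlorophenyl on an amide-type nitrogen. For the measured compounds named here, the one measured step, from compound 1 to compound 2, concerns a nitro in place of chloro on an aromatic carbon and stayed within the scatter; it does not touch the amide-type nitrogen and so bears only loosely on the present change. Going by the values given here, with no direct precedent, the account expects at most a modest step, if any, towards a higher number in this assay, a 1.5-fold higher number from compound 1 to compound 3 (0.17 log units; within the scatter). Compound 3 is therefore estimated at 10000 nM, with a range from 4000 nM to 30000 nM.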

Compound 3, half-maximal cytotoxic concentration: 43000 nM
Estimate against measurement, compound 3: 4.3-fold (0.63 log units) below; the measured number lies above the stated range.
By their numbers in this assay, from the lowest: compounds 1 and 2 (each within the scatter of the next); then compound 3.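

The nitrogen position responds in this assay where the aromatic carbon changed in compound 2 did not: 3-(methylsulfanyl)propyl in place of 4-chlorophenyl gives a step beyond the scatter (a 6.3-fold higher number from compound 1 to compound 3 (0.80 log units; beyond the scatter)). So on this side of the shared core, the aromatic ring is not needed for the compound to be measured in this assay, and its replacement by an open chain goes with more compound being tolerated. Nothing measured here accounts for the step.

The single change removes the ring and the chlorine and brings in the chain and its sulfur together, so the compounds shown cannot say which of these matters. A plain butyl chain, a 3-methoxypropyl group or a cyclohexyl ring on the same nitrogen would begin to separate them.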